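The source may hold more compounds than are shown below. What is called first, only, known or untested is meant among the compounds shown, and "the series" means these compounds.

Three compounds have so far been tested in a functional assay on MDA-MB-435 cells (Homo sapiens) for cytotoxicity, read by sulforhodamine B assay, with a stated time of 48 h, tested at 100 uM; on this read-out higher numbers stand for a weaker effect at the one concentration tested and lower numbers for a stronger effect:

Compound 1, `COc1ccc(-c2cc(/C=C/C(=O)c3ccc(N)cc3)[nH]n2)cc1`, gives -75%.
Compound 2, `COc1ccc(C(=O)/C=C/c2cc(-c3cc(OC)c(OC)c(OC)c3)n[nH]2)cc1OC`, gives -73%.
Compound 3, `COc1ccc(-c2cc(/C=C/C(=O)c3ccc(N)cc3)[nH]n2)cc1OC`, gives -72%.

Compound 1 and compound 3 differ in a single place: methoxy in place of hydrogen on an aromatic carbon. The step that goes with this change is a number 3 percentage points higher from compound 1 to compound 3 (within the scatter), so the two numbers cannot be told apart. Compound 2 is built on a different core from compound 1, and the difference between the two cores is not broken down here. In this assay compound 2 and compound 3 sit within the scatter of each other, and the same holds for compound 2 and compound 1, so no order among the three can be claimed.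

Compound 4, `COc1cc(C(=O)/C=C/c2cc(-c3cc(OC)c(OC)c(OC)c3)n[nH]2)cc(OC)c1OC`, has not yet been measured. It comes from compound 2 by methoxy in place of hydrogen on an aromatic carbon. Among the compounds with values here, this is the same kind of change as the one from compound 1 to compound 3, but the surroundings are not identical: in compound 4 the place is also meta to a methoxy group, which is not so in compound 3. Within the data shown here, since the one measured example of this change, a number 3 percentage points higher from compound 1 to compound 3 (within the scatter), stayed within the scatter, the step from compound 2 to compound 4 is expected to be no change at the digits printed from compound 2 to compound 4 (within the scatter). On that basis compound 4 is estimated to give -73% in this assay, with a range from -85% to -60%.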

Compound 4, a percentage reported as activity, at one concentration (the size of the read-out at that concentration, not a potency): -83%
Compound 4: the middle estimate sits 10 percentage points above what was measured; the measured number falls inside the stated range.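

Replacing a hydrogen on an aromatic carbon with a methoxy group gives, in this assay, a number 10 percentage points lower from compound 2 to compound 4 (within the scatter), so this second example of the change also stays within the usual scatter of repeated measurements. Set side by side, the results on the two cores cannot be told apart: the same change on two cores in this assay, a number 3 percentage points higher (within the scatter) from compound 1 to compound 3 and a number 10 percentage points lower (within the scatter) from compound 2 to compound 4, 13 percentage points apart, within the scatter of two such steps. This means that, in this small series, nothing shows the core altering what the change does, and on neither core can the added methoxy group be said to have any effect on the read-out; however, two steps that both sit within the scatter do not prove that the change behaves identically on both cores, since a real but small difference could be hidden in that scatter.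

The compounds shown leave open whether a different group in the same place, such as ethoxy, a hydroxyl group or a fluorine atom, would give a step that clearly exceeds the scatter. They also leave open whether the methoxy change would stay as quiet on a third core, for example one carrying a carboxylic acid on its aromatic ring.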